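The source may report more compounds than this note shows. Statements on the series, on what has been measured and on what is new or still open speak of the compounds shown alone.

Compound 1 `CCOC(=O)/C=C/c1ccncc1-c1ccc2[nH]ccc2c1` carries the ethyl ester on the shared core. In a functional assay on KB cells (Homo sapiens) for inhibition, read by sulforhodamine B assay, with a stated time of 72 h (on this read-out higher numbers stand for weaker inhibition of growth and lower numbers for stronger inhibition of growth), compound 1 gives > 10000 nM, which is a limit of the assay rather than a number. Compound 2 `CNC(=O)/C=C/c1ccncc1-c1ccc2ccccc2c1` gives > 10000 nM, also a limit. Compound 3 `CN1CCN(C(=O)/C=C/c2ccncc2-c2ccc3ccccc3c2)CC1` gives > 10000 nM, again a limit. Among the measured compounds shown here, the only measured step, a step that the two limits leave unreadable from compound 2 to compound 3, is therefore of unreadable size, and the limit of > 10000 nM in this assay, at which 3 of the 3 values shown sit, shows all three values sitting together. Compound 4 `O=C(O)/C=C/c1ccncc1-c1ccc2[nH]ccc2c1` differs from compound 1 by hydrogen in place of ethyl on an oxygen next to a carbonyl group. For the measured compounds named here, no measured step bears on this change, so neither direction nor size can be drawn from the series. Compound 4 is estimated at 15000 nM, with a range from 5000 nM to 50000 nM. The expected step that the limit leaves unreadable from compound 1 to compound 4 is taken as none beyond the scatter.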

Compound 4, concentration for 50% growth inhibition: > 10000 nM
Compound 4: a limit, no number; the forecaster's own chance of this, stated with the estimate: 85%; the middle value does not contradict the limit.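

Compound 1 and compound 4 both stand at a limit, not a number, so no step between them can be read: the limit of > 10000 nM in this assay, at which 4 of the 4 values shown sit.

The compounds shown leave open what change on the shared core, if any, gives a readable number in this assay.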